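Methyl for Methoxy on Two Different Rings

The source may hold more compounds than are shown below. What is called first, only, known or untested is meant among the compounds shown, and "the series" means these compounds.

Measured so far:
compound 1, `CCCc1ccc(-c2cc(OC)cc(C(=O)Nc3nn[nH]n3)n2)cc1`, 32%
compound 2, `COc1ccc(-c2cccc(C(=O)Nc3nn[nH]n3)n2)cc1`, 4%
compound 3, `Cc1ccc(-c2cccc(C(=O)Nc3nn[nH]n3)n2)cc1`, 21%

All three were tested in a functional assay on the whole organism for inhibition, with Rattus norvegicus as the target, at a dose of 0.3 mg/kg by the oral route; a lower number here means a weaker effect, a higher number a stronger effect of the compound at the dose given. Compound 2 gives 4% and compound 3 gives 21%; the two differ in one place, (methyl in place of methoxy on an aromatic carbon), and the step is a number 17 percentage points higher from compound 2 to compound 3 (beyond the scatter). Compound 1 gives 32%, the highest of the three numbers, but the difference between the core of compound 1 and the core of compound 2 is not broken down here.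

The unmeasured compound 4, `CCCc1ccc(-c2cc(C)cc(C(=O)Nc3nn[nH]n3)n2)cc1`, is made from compound 1 by the same kind of change: methyl in place of methoxy on an aromatic carbon. The earlier step took place on a six-membered aromatic ring of carbon only, para to a large group, while here the change sits on a six-membered aromatic ring with one nitrogen, meta to the (2H-tetrazol-5-yl)carbamoyl group and opposite the ring nitrogen. The place is thus not the same. The earlier step is only a loose guide.

In this assay, within the data shown here, compound 4 is expected to gain about a number 8 percentage points higher from compound 1 to compound 4 (within the scatter), a smaller step than the one from compound 2 to compound 3, because only a number 17 percentage points higher from compound 2 to compound 3 (beyond the scatter) is known for this kind of change and it was made on a different ring. Compound 4 is therefore estimated at 40%, with a likely range from 22% to 58%.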

Compound 4, a percentage reported as inhibition, in the whole organism at one dose (the size of the read-out at that dose, not a potency): 19%
Compound 4: the middle estimate sits 21 percentage points above what was measured; the measured number lies below the stated range.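

In this assay, putting methyl in place of methoxy on the ring with one nitrogen, opposite the ring nitrogen, gives a number 13 percentage points lower from compound 1 to compound 4 (beyond the scatter). Among these compounds, the same swap therefore does not carry a fixed gain from one core to another, and here even its direction reverses: the same change on two cores in this assay, a number 17 percentage points higher (beyond the scatter) from compound 2 to compound 3 and a number 13 percentage points lower (beyond the scatter) from compound 1 to compound 4, 30 percentage points apart, beyond the scatter of two such steps What this does not show is which difference between the two cases decides the outcome, since the swap sits at a different place in each and the two starting compounds also differ elsewhere, with only one pair for each core and nothing here to separate the place of the change from the rest of the molecule.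

The compounds shown leave open what an ethoxy group, a chlorine atom or an amine would give on that same aromatic carbon, which would tell whether methoxy stands out there or methyl simply falls short. They also leave open whether these steps would keep their size and direction at other doses, as each read-out gives the size of the effect at a single oral dose and is not a potency.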